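Biaryl in place of the bromoethoxy chain on the flavone core

The source may report more compounds than this note shows. Statements on the series, on what has been measured and on what is new or still open speak of the compounds shown alone.

Measured so far:
compound 1, `COc1cc(OC)c2c(=O)cc(-c3ccc(OCCBr)cc3)oc2c1`, in a functional assay (Homo sapiens) for antiproliferative activity, read by resazurin assay, with a stated time of 48 h, tested at 10 uM (a lower number here means a weaker effect, a higher number a stronger effect of the compound at the concentration tested), compound 1 gives "not active" (no number reported)
compound 2, `COc1cc(OC)c2c(=O)cc(-c3ccc(OCCN)cc3)oc2c1`, in this assay compound 2 gives 35%
compound 3, `COc1cc(OC)c2c(=O)cc(-c3ccc(OCC(O)CO)cc3)oc2c1`, in this assay compound 3 gives 11%

Compound 1 stands without a number in this assay: it is reported as not active at the concentration tested, so it cannot be placed on the scale next to compound 2 or compound 3. Among the two numbered compounds, the one measured step, a number 24 percentage points lower from compound 2 to compound 3 (beyond the scatter), concerns the chain bound to the aromatic oxygen and leaves the shared core untouched.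

Compound 4, `COc1cc(OC)c2c(=O)cc(-c3ccc(-c4ccc(F)nc4)cc3)oc2c1`, is not yet measured. Relative to compound 1 it differs as follows: 6-fluoropyridin-3-yl in place of 2-bromoethoxy on an aromatic carbon. The change replaces the whole oxygen-linked chain with a second aromatic ring carrying a nitrogen and a fluorine, on the aromatic carbon para to a large group. Within the data shown here, none of the measured steps bears on this change; the step from compound 2 to compound 3 only exchanges one chain end for another on the same oxygen-linked chain, which is absent in compound 4. What the three measured compounds show is that the whole set sits in the weak range of this assay, with compound 1 not reaching a reportable number.

For compound 4 a weak effect in this assay is therefore expected, estimated at 20% with a range from 0% to 50%.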

Compound 4, a percentage reported as inhibition, at one concentration (the size of the read-out at that concentration, not a potency): 6%
Estimate against measurement, compound 4: 14 percentage points above, within the range that was stated.
By their numbers in this assay, from the lowest: compounds 4 and 3 (each within the scatter of the next); then compound 2.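

Among these compounds, compound 4 is the first compound here with no oxygen-linked chain on this aromatic carbon, and with a 6-fluoropyridin-3-yl ring in that place it still gives a number in this assay. Set against the 2,3-dihydroxypropoxy chain, the ring gives no separable change (a number 5 percentage points lower from compound 3 to compound 4 (within the scatter)), whereas set against the 2-aminoethoxy chain it gives a real loss (a number 29 percentage points lower from compound 2 to compound 4 (beyond the scatter)), so among the compounds with numbers only the one carrying the amine-ended chain stands apart, and a chain on the oxygen is not required to match the level of compound 3. No measured evidence accounts for these differences.

Open, as far as these compounds go, is whether the higher number of compound 2 depends on the primary amine itself, which a dimethylamino group, a piperidine or a carboxylic acid at the end of the same ethoxy chain would address. Also open, from the compounds shown here alone, is what the ring of compound 4 contributes through its nitrogen and its fluorine, which a plain phenyl ring or an unsubstituted pyridin-3-yl ring on the same aromatic carbon would separate.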